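Dichloro for fluoro at the phenyl on the shared core

The source may hold more compounds than are shown below. What is called first, only, known or untested is meant among the compounds shown, and "the series" means these compounds.

Measured so far:
compound 1, `O=C1COc2ccc(-c3[nH]c(-c4ccccc4)nc3-c3ccccc3)cc2N1`: 58.5%
compound 2, `O=C1COc2ccc(-c3[nH]c(-c4ccc(F)cc4)nc3-c3ccccc3)cc2N1`: 37.5%

In a functional assay on A549 cells (Homo sapiens) for cytotoxicity, read by colorimetric assay and MTT assay, with a stated time of 3 days, tested at 20 uM (a lower number here means a stronger effect, a higher number a weaker effect of the compound at the concentration tested), compound 1 gives 58.5% and compound 2 gives 37.5%. Among the compounds with values here, the only measured step, a number 21 percentage points lower from compound 1 to compound 2 (beyond the scatter), leaves compound 2 with the lowest of the two numbers, its nearest neighbour being compound 1.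

Compound 3, `O=C1COc2ccc(-c3[nH]c(-c4ccc(Cl)cc4Cl)nc3-c3ccccc3)cc2N1`, has not been measured in this assay. The change from compound 2 is 2,4-dichlorophenyl in place of 4-fluorophenyl on an aromatic carbon. Within the data shown here, no measured pair shows exactly this exchange; the one step that bears on it, a number 21 percentage points lower from compound 1 to compound 2 (beyond the scatter), shows that putting a halogen onto this phenyl moved the number modestly, beyond the scatter. With a halogen kept on that ring and a second one added, compound 3 is expected to land near compound 2, with the step of a number 2.5 percentage points lower from compound 2 to compound 3 (within the scatter) expected to stay within the scatter. The estimate for compound 3 is 35%, within 15% to 60%.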

Compound 3, a percentage reported as activity, at one concentration (the size of the read-out at that concentration, not a potency): 68.3%
Beside the measured number, compound 3's estimate is 33.3 percentage points below it, and the stated range ends below it.
By their numbers in this assay, from the lowest: compound 2; then compounds 1 and 3 (each within the scatter of the next).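

Replacing 4-fluorophenyl with 2,4-dichlorophenyl at this position of the shared core in this assay gives a number 30.8 percentage points higher from compound 2 to compound 3 (beyond the scatter), a large step that reverses the earlier gain instead of extending it. Against the unsubstituted phenyl group, the same 2,4-dichlorophenyl group gives a number 9.8 percentage points higher from compound 1 to compound 3 (within the scatter), so halogen on this ring does not in itself go with the lower number seen for compound 2. No measurement offered here explains why these two halogenated rings differ.

The compounds shown leave open whether the step follows from the kind of halogen, the number of halogens or their placement on the ring, which 4-chlorophenyl and 2-chlorophenyl would help separate. They also leave open how a non-halogen group on this ring, such as methoxy or an amine, would read.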